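This account rests on a few compounds, and the source may have more. Where it says the series, first, only, none or still open, it means among the compounds named here.

Compound 1 `CCOc1cccc(S(=O)(=O)Nc2ccc(N3CCN(c4cccc(-c5c(C(=O)NCCCN6CCN(C)CC6)c(C)n(C)c5-c5ccc(Cl)cc5)c4)CC3)cc2)c1` carries an ethoxy group on the outer aromatic ring of its sulfonamide, and in an assay for binding affinity to Apoptosis regulator Bcl-2 (Homo sapiens), read by fluorescence polarization, with a stated time of 2 h (a higher number here means a weaker inhibitor, a lower number a stronger inhibitor), compound 1 gives 420 nM. Compound 2 `Cc1cccc(S(=O)(=O)Nc2ccc(N3CCN(c4cccc(-c5c(C(=O)NCCCN6CCN(C)CC6)c(C)n(C)c5-c5ccc(Cl)cc5)c4)CC3)cc2)c1` differs from it only in the group on that aromatic carbon, and in this assay compound 2 gives 178 nM. Going by the values given here, the single measured step, a 2.4-fold lower number from compound 1 to compound 2 (0.37 log units; beyond the scatter), is the only one-point change available here. Compound 3 `Cc1c(C(=O)O)c(-c2cccc(N3CCN(c4ccc(NS(=O)(=O)c5ccc(N[C@H](CCN6CCC(O)CC6)CSc6ccccc6)c(S(=O)(=O)C(F)(F)F)c5)cc4)CC3)c2)c(-c2ccc(Cl)cc2)n1C(C)C` is built on the same core but differs from compound 2 in several places at once, including a carboxylic acid in place of the amide tail and a much larger sulfonamide portion; in this assay compound 3 gives 0.8 nM. Compound 2 therefore stands second highest of the three numbers, beyond the scatter from compound 1 and very far above compound 3.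

Compound 4 `Cc1c(C(=O)NCCCN2CCN(C)CC2)c(-c2cccc(N3CCN(c4ccc(NS(=O)(=O)c5cccc(S(=O)(=O)C(F)(F)F)c5)cc4)CC3)c2)c(-c2ccc(Cl)cc2)n1C` is the next step from compound 2: (trifluoromethyl)sulfonyl in place of methyl on an aromatic carbon. Among the compounds with values here, no measured step covers this exact exchange; the step from compound 1 to compound 2 shows that a small change on this aromatic carbon can shift the number modestly, while compound 3, which also contains a (trifluoromethyl)sulfonyl group among many other differences, reaches a far lower number. On this basis compound 4 is expected to show a 1.8-fold lower number from compound 2 to compound 4 (0.25 log units; within the scatter), a modest improvement. The estimated value for compound 4 is 100 nM, within a range from 30 nM to 400 nM.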

Compound 4, inhibition constant: 39.2 nM
Compound 4: the middle estimate sits 2.6-fold (0.41 log units) above what was measured, within the range that was stated.
By their numbers in this assay, from the lowest: compound 3; then compound 4; then compound 2; then compound 1.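

In this assay, the aromatic carbon that held ethoxy or methyl now carries (trifluoromethyl)sulfonyl, and the number falls further: the exchange for methyl gives a 4.5-fold lower number from compound 2 to compound 4 (0.66 log units; beyond the scatter) and the exchange for ethoxy gives an 11-fold lower number from compound 1 to compound 4 (1.03 log units; beyond the scatter) on the shared core. Until now, this position had shown only a modest difference between two small groups; with this third group, it shows a large step, and the order of the three, all separated beyond the scatter, does not follow group size, since ethoxy gives a higher number than methyl while the much larger (trifluoromethyl)sulfonyl gives the lowest. No measurement at hand accounts for this gain in binding.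

Still open, as far as these compounds go, is which part of the new group carries the step, since a plain methylsulfonyl or a trifluoromethyl on this carbon would separate the sulfonyl from the fluorinated part, and a nitrile would test a smaller group. From the compounds shown here alone, it is also open whether the same exchange would give a step of similar size with a carboxylic acid in place of the amide tail.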